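A Second Chlorine on the Benzyl Ring of Compound 1

The compounds below may be only part of what the source reports. "The series", "measured", "known", "first", "only" and "open" are said of these compounds alone.

Compound 1 `O=C1Nc2ccc(OCc3cccc(Cl)c3)cc2C1=O` is the stronger of two measured compounds. In an assay on cells for inhibition of Amine oxidase [flavin-containing] B (Homo sapiens), read by fluorescence, with stated times of 30 min and 15 min (a higher number here means a weaker inhibitor, a lower number a stronger inhibitor), compound 1 gives 46 nM, while compound 2 `CC1(C)C(=O)Nc2ccc(OCc3ccc(Cl)c(Cl)c3)cc21` gives 132000 nM in this assay; the two differ in more than one place, so the gap tells nothing about any single change. Compound 3 `O=C1Nc2ccc(OCc3ccc(Cl)c(Cl)c3)cc2C1=O` carries the change (chloro in place of hydrogen on an aromatic carbon), chloro in place of hydrogen on an aromatic carbon, ortho to a chloro group and para to a large group. For the measured compounds named here, no such single step has been measured here, so the expected step of a 1.3-fold lower number from compound 1 to compound 3 (0.12 log units; within the scatter) is small, within the scatter. Compound 3 is expected to give 35 nM, between 8 nM and 150 nM.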

Compound 3, half-maximal inhibitory concentration: 3 nM
For compound 3 the middle estimate is 12-fold (1.07 log units) above the measured one; measured number below the stated range.
By their numbers in this assay, from the lowest: compound 3; then compound 1; then compound 2.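

In this assay, chloro in place of hydrogen on this aromatic carbon, ortho to a chloro group and para to a large group, gives a 15-fold lower number from compound 1 to compound 3 (1.19 log units; beyond the scatter) and so shows that this one position can change the number strongly. The earlier pair could not show this, since those compounds differ in more than one place. Nothing available explains the size of this step. 

On these data alone, whether a different group on this carbon, such as fluoro, methoxy or an amine, would give a similar step remains open.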